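This account rests on a few compounds, and the source may have more. Where it says the series, first, only, none or still open, it means among the compounds named here.

Compound 1 `O=C(/C=C/c1cccnc1)NCCCCCCc1cccc(S(=O)(=O)Nc2ccccc2)c1`: 0.88 nM
Compound 2 `Cc1ccc(NS(=O)(=O)c2cccc(CCCCCCNC(=O)/C=C/c3cccnc3)c2)cc1`: 2.98 nM
Compound 3 `CCc1ccc(NS(=O)(=O)c2cccc(CCCCCCNC(=O)/C=C/c3cccnc3)c2)cc1`: 3.89 nM

These values come from a functional assay on K562 cells (Homo sapiens) for inhibition, read by CCK-8 assay, with a stated time of 72 h; a lower number here means a stronger inhibitor, a higher number a weaker inhibitor. In this series, compound 3 sits close to the methyl-bearing analogue, a 1.3-fold higher number from compound 2 to compound 3 (0.12 log units; within the scatter), but clearly apart from the analogue without an added group, a 4.4-fold higher number from compound 1 to compound 3 (0.65 log units; beyond the scatter).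

The next structure is compound 4 `CC(C)(C)c1ccc(NS(=O)(=O)c2cccc(CCCCCCNC(=O)/C=C/c3cccnc3)c2)cc1`, which has tert-butyl in place of ethyl on an aromatic carbon, para to a large group: tert-butyl in place of ethyl on an aromatic carbon.

For the measured compounds named here, three measured steps bear on this change. Placing a group on that ring carbon raised the number modestly each time, a 3.4-fold higher number from compound 1 to compound 2 (0.53 log units; beyond the scatter) and a 4.4-fold higher number from compound 1 to compound 3 (0.65 log units; beyond the scatter). Growing methyl to ethyl, however, made only a small difference, a 1.3-fold higher number from compound 2 to compound 3 (0.12 log units; within the scatter). Going by the values given here, a further increase in group size therefore points to a small rise in this assay, possibly lost in the scatter, although no measured compound carries a group as large as tert-butyl.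

The expected change is a 1.4-fold higher number from compound 3 to compound 4 (0.15 log units; within the scatter). Compound 4 is estimated at 5.5 nM, with an expected range of 2 nM to 14 nM.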

Compound 4, half-maximal inhibitory concentration: 24.7 nM
Beside the measured number, compound 4's estimate is 4.5-fold (0.65 log units) below it; the measured number lies above the stated range.
By their numbers in this assay, from the lowest: compound 1; then compounds 2 and 3 (each within the scatter of the next); then compound 4.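

In this assay, the near-flat stretch from methyl to ethyl does not continue to tert-butyl: this change gives a clear jump (a 6.3-fold higher number from compound 3 to compound 4 (0.80 log units; beyond the scatter)), although compounds 2 and 3 lie within the scatter of each other. The gap widens against the smaller substituents (an 8.3-fold higher number from compound 2 to compound 4 (0.92 log units; beyond the scatter)) and against the unsubstituted ring (a 28-fold higher number from compound 1 to compound 4 (1.45 log units; beyond the scatter)), so this ring carbon tolerates methyl and ethyl far better than tert-butyl. No evidence shown explains the sharp rise.

The compounds shown cannot separate the number of carbons from branching, a question that isopropyl and straight-chain butyl groups at this position could help settle. Going by these compounds, whether groups with atoms other than carbon and hydrogen, such as methoxy or an amine, would also raise the number remains open.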